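Methylamino in place of amino: working notes on the series

The source may hold more compounds than are shown below. What is called first, only, known or untested is meant among the compounds shown, and "the series" means these compounds.

In a functional assay on A549 cells (Homo sapiens) for antiproliferative activity, read by MTT assay, with a stated time of 48 h (on this read-out higher numbers stand for weaker inhibition and lower numbers for stronger inhibition), three compounds share one core and differ in the group on the saturated chain carbon bound to a carbonyl carbon. Compound 1 `COc1ccc(C(=O)c2ccc3c(c2)C=CC(C)(C)O3)c(NC(=O)CBr)c1` gives 1980 nM, compound 2 `COc1ccc(C(=O)c2ccc3c(c2)C=CC(C)(C)O3)c(NC(=O)CO)c1` gives 90 nM, and compound 3 `COc1ccc(C(=O)c2ccc3c(c2)C=CC(C)(C)O3)c(NC(=O)CN)c1` gives 310 nM, the second highest of the three numbers.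

Compound 4 `CNCC(=O)Nc1cc(OC)ccc1C(=O)c1ccc2c(c1)C=CC(C)(C)O2` carries methyl in place of hydrogen on an amine nitrogen, amino to methylamino: methyl in place of hydrogen on an amine nitrogen.

The closest evidence comes from exchanges of the whole group on that chain carbon: a 3.4-fold higher number from compound 2 to compound 3 (0.54 log units; beyond the scatter) and a 6.4-fold lower number from compound 1 to compound 3 (0.81 log units; beyond the scatter), both modest, and a 22-fold lower number from compound 1 to compound 2 (1.34 log units; beyond the scatter), large. For the measured compounds named here, no measured step alters the amine nitrogen itself, so these steps bear on the change only indirectly. The amino group stays in place, with one added methyl, so a smaller step than any of these is expected. In this assay, the estimated step is a 1.1-fold higher number from compound 3 to compound 4 (0.05 log units; within the scatter), with no shift beyond the scatter expected. Compound 4 is estimated at 350 nM, with an expected range of 130 nM to 900 nM.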

Compound 4, half-maximal inhibitory concentration: 800 nM
The estimate for compound 4 lay 2.3-fold (0.36 log units) below the measured number; measured number inside the range.
By their numbers in this assay, from the lowest: compound 2; then compound 3; then compound 4; then compound 1.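

In this assay, for the compounds shown here, the amine nitrogen itself turns out to matter: one added methyl gives a 2.6-fold higher number from compound 3 to compound 4 (0.41 log units; beyond the scatter) and this is the first measured change at that nitrogen. Methylamino still improves on bromo, with a 2.5-fold lower number from compound 1 to compound 4 (0.39 log units; beyond the scatter) on the saturated chain carbon bound to a carbonyl carbon, but it trails hydroxy further than amino does, with an 8.9-fold higher number from compound 2 to compound 4 (0.95 log units; beyond the scatter) as the step, so compound 2 keeps the lowest number of the four. Nothing shown gives a measured reason for the rise on adding the methyl.

As far as these compounds go, whether dimethylamino or ethylamino in that place would raise the number further remains open. Also open, from the compounds shown here alone, is whether methoxy on the same chain carbon would keep the low number seen with hydroxy.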